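The compounds below may be only part of what the source reports. "The series", "measured", "known", "first", "only" and "open" are said of these compounds alone.

Measured in a physicochemical assay for acid dissociation:
compound 1 `COc1ccc(-c2ccc3c(NCCCNCc4cccc(OC)c4O)ccnc3c2)cc1`, compound 1 gives 9.47
compound 2 `COc1cccc(CNCCCNc2ccnc3cc(C4CCCCC4)ccc23)c1O`, compound 2 gives 9.47
compound 3 `COc1cccc(CNCCCNc2ccnc3cc(CCC(C)C)ccc23)c1O`, compound 3 gives 9.47

Compound 3 stands level with compounds 1 and 2 at the digits shown; the three values sit within the scatter of one another, so none can be ordered against the others.

Compound 4 `COc1cccc(CNCCCNc2ccnc3cc(Oc4cccc(N(C)C)c4)ccc23)c1O` is the next member, unmeasured in this assay. It differs from compound 3 by 3-(dimethylamino)phenoxy in place of isopentyl on an aromatic carbon.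

Among the compounds with values here, three measured steps bear on this, all of them exchanges at the same aromatic carbon: no change at the digits printed from compound 1 to compound 2 (within the scatter), no change at the digits printed from compound 1 to compound 3 (within the scatter) and no change at the digits printed from compound 2 to compound 3 (within the scatter). Each exchanged one group for another at that position without any shift beyond the scatter, whether an aryl, a saturated ring or a branched chain occupied it. The new group in compound 4 is again an exchange at that carbon, so the expectation for this assay is a step of no change at the digits printed from compound 3 to compound 4 (within the scatter) from compound 3 to compound 4, that is, none beyond the scatter. The estimate for compound 4 is therefore 9.47, with a range from 9.1 to 9.8.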

Compound 4, acid dissociation constant: 9.28
The estimate for compound 4 lay 0.19 log units above the measured number, within the range that was stated.
By their numbers in this assay, from the lowest: compounds 4, 1, 2 and 3 (each within the scatter of the next).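

In this assay, 3-(dimethylamino)phenoxy at this aromatic carbon gives a number 0.19 log units lower from compound 3 to compound 4 (within the scatter), a number 0.19 log units lower from compound 2 to compound 4 (within the scatter) and a number 0.19 log units lower from compound 1 to compound 4 (within the scatter). The exchanges that stay within the scatter at this carbon therefore now extend beyond aryl, saturated ring and branched chain to a phenoxy group bearing a dimethylamino substituent, the first entry here with a second nitrogen in the exchanged group. No measurement is available that bears on the origin of these small differences.

Going by these compounds, whether a carboxylic acid or a piperazine at this aromatic carbon would move the number in this assay beyond the scatter stays open. The compounds shown differ only at this one carbon, so they say nothing about an exchange elsewhere on the shared core.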